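The compounds below may be only part of what the source reports. "The series", "measured", "known", "first", "only" and "open" are said of these compounds alone.

Measured compounds:
compound 1, `Nc1ncnc2c1ncn2[C@@H]1O[C@H](COS(=O)(=O)NC(=O)[C@@H]2CCN2)[C@@H](O)[C@H]1O`, giving 600 nM in a functional assay on PBMC cells (Homo sapiens) for inhibition; a higher number here means a weaker inhibitor, a lower number a stronger inhibitor;
compound 2, `CSCC[C@H](N)C(=O)NS(=O)(=O)OC[C@H]1OC[C@@H](n2cnc3c(N)ncnc32)C[C@@H]1O`, giving 5500 nM in this assay.

Compound 1 holds the lower of the two numbers in this assay. Among the compounds with values here, compound 2 sits well beyond the scatter above it, but the two compounds differ in more than one place, so their gap shows only what the two values are and supports no single step. The unmeasured compound 3, `N=C(N)NCCC[C@H](N)C(=O)NS(=O)(=O)OC[C@H]1O[C@@H](n2cnc3c(N)ncnc32)[C@H](O)[C@@H]1O`, differs from compound 1 in one place: a group of 9 heavy atoms (5 carbon, 4 nitrogen; no ring) in place of a group of 4 heavy atoms (3 carbon, 1 nitrogen; one four-membered non-aromatic ring with 1 hetero atom), on a carbonyl carbon. Within the data shown here, no step between measured compounds isolates a change of this kind, so the direction rests on little. The account expects a modest move toward a higher number, the step of a 2.5-fold higher number from compound 1 to compound 3 (0.40 log units; beyond the scatter), while a step within the scatter cannot be excluded. Compound 3 is estimated at 1500 nM, with a range from 300 nM to 8000 nM.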

Compound 3, half-maximal inhibitory concentration: 1000 nM
Estimate against measurement, compound 3: 1.5-fold (0.18 log units) above; the range from low to high includes it.
By their numbers in this assay, from the lowest: compounds 1 and 3 (each within the scatter of the next); then compound 2.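

Within the data shown here, compound 1 and compound 3 give the first comparison in which only one place changes. In this assay, replacing azetidin-2-yl on the carbonyl carbon with a group of 9 heavy atoms and no ring gives a 1.7-fold higher number from compound 1 to compound 3 (0.22 log units; within the scatter), so the shared core reads alike with either group at this position. Nothing measured here explains this result.

Steps to compound 2 cannot be read, since it differs from the others in more than one place, and the contribution of its side chain to the value therefore stays unresolved. From the compounds shown here alone, it also remains open whether a carboxylic acid, a phenyl ring or a longer chain without nitrogen on this carbonyl carbon would stay within the scatter of these two compounds or move clearly away from them.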